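Series notes: compound 4 against compound 3

The source may report more compounds than this note shows. Statements on the series, on what has been measured and on what is new or still open speak of the compounds shown alone.

Compound 3 `NC(=O)c1c(NC(=O)c2ccccc2Cl)sc2c1CCN(C(=S)Nc1ccccc1C(F)(F)F)C2` in a functional assay on HeLa cells (Homo sapiens) for antiproliferative activity, with a stated time of 24 h (a lower number here means a stronger inhibitor, a higher number a weaker inhibitor), gives 26700 nM; compound 1 `NC(=O)c1c(NC(=O)c2cccc([N+](=O)[O-])c2)sc2c1CCN(Cc1c(Cl)cccc1Cl)C2` gives 46100 nM and compound 2 `NC(=O)c1c(NC(=O)c2ccccc2Cl)sc2c1CCN(C(=S)Nc1ccccc1)C2` gives 46700 nM, both within the scatter of compound 3, so no order among the three can be read from these numbers. Going by the values given here, the one step on the shared core, a 1.7-fold lower number from compound 2 to compound 3 (0.24 log units; within the scatter), also stays within the scatter. Compound 4 `NC(=O)c1c(NC(=O)c2ccccc2Cl)sc2c1CCN(C(=S)Nc1ccc(C(F)(F)F)cc1)C2` differs from compound 3 by 4-(trifluoromethyl)phenyl in place of 2-(trifluoromethyl)phenyl on an amide-type nitrogen. Among the compounds with values here, no measured step compares a 2-(trifluoromethyl)phenyl with a 4-(trifluoromethyl)phenyl, and the only step involving the trifluoromethyl group did not rise above the scatter, so no change beyond the scatter is expected in this assay. Compound 4 is therefore estimated at 30000 nM (range 12000 nM to 75000 nM), an expected step of a 1.1-fold higher number from compound 3 to compound 4 (0.05 log units; within the scatter).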

Compound 4, half-maximal inhibitory concentration: > 50000 nM
Compound 4 was reported as a limit (the forecaster's own chance of this, stated with the estimate: 10%); middle value at least 1.6-fold (0.22 log units) away from the limit.
By their numbers in this assay, from the lowest: compounds 3, 1 and 2 (each within the scatter of the next). At a limit, above all of these: compound 4.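

In this assay compound 4 gives > 50000 nM, which is a limit and not a number. Going by these compounds alone, this is the first reading of the 4-(trifluoromethyl)phenyl against the 2-(trifluoromethyl)phenyl on the amide-type nitrogen: an at least 1.8-fold higher number from compound 3 to compound 4 (0.27 log units; that floor lies within the scatter). Trifluoromethyl in place of hydrogen at the 4-position of that phenyl reads an at least 1.0-fold higher number from compound 2 to compound 4 (0.02 log units; that floor lies within the scatter), so neither floor establishes a change. Open, going by these compounds, is the size of either step, since compound 4 carries no number. Also open, on these data alone, is how a methoxy group or a nitrile in place of the trifluoromethyl would read on this phenyl.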